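This account rests on a few compounds, and the source may have more. Where it says the series, first, only, none or still open, it means among the compounds named here.

Measured compounds in a functional assay on U-87MG ATCC cells (Homo sapiens) for antiproliferative activity, read by MTT assay, with a stated time of 48 h; a higher number here means a weaker inhibitor, a lower number a stronger inhibitor:
- compound 1, `COc1ccc(-c2nn(-c3ccccc3)cc2C(=O)/C=C\Nc2cc(OC)c(OC)c(OC)c2)cc1` — gives > 50000 nM, a limit of the assay, not a number
- compound 2, `COc1cc(-c2nn(-c3ccccc3)cc2C(=O)/C=C\Nc2ccc(Cl)cc2)cc(OC)c1OC` — gives 3210 nM
- compound 3, `COc1cc(-c2nn(-c3ccccc3)cc2C(=O)/C=C\Nc2ccc(C(F)(F)F)cc2)cc(OC)c1OC` — gives > 50000 nM, again a limit of the assay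

Compound 3 stands at the upper limit; its value is a limit and not a number, and the limit of > 50000 nM in this assay, at which 2 of the 3 values shown sit, shows that this is where two of the three values sit. Within the data shown here, the one measured step that reaches it is an at least 15-fold higher number from compound 2 to compound 3 (1.19 log units; beyond the scatter), a large step whose size is only a lower bound because of that limit.

Compound 4, `COc1cc(N/C=C\C(=O)c2cn(-c3ccccc3)nc2-c2cc(OC)c(OC)c(OC)c2)cc(OC)c1OC`, differs from compound 3 by 3,4,5-trimethoxyphenyl in place of 4-(trifluoromethyl)phenyl on an amine nitrogen. Among the measured compounds shown here, no measured step covers this change directly. Compound 1 also carries a 3,4,5-trimethoxyphenyl on an amine nitrogen, and its value in this assay is a limit. On that basis the expectation for compound 4 is that it stays near the limit rather than recovering the number of compound 2, and the estimated step is an at least 1.6-fold lower number from compound 3 to compound 4 (0.22 log units; that floor lies within the scatter), not clearly beyond the scatter. Compound 4 is therefore estimated at 30000 nM, with a range from 5000 nM to 50000 nM.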

Compound 4, half-maximal inhibitory concentration: 5100 nM
For compound 4 the middle estimate is 5.9-fold (0.77 log units) above the measured one; low and high end bracket the measured number.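

In this assay, among these compounds, the amine nitrogen proves more permissive than the earlier compounds indicated: 3,4,5-trimethoxyphenyl in place of 4-(trifluoromethyl)phenyl gives an at least 9.8-fold lower number from compound 3 to compound 4 (0.99 log units; beyond the scatter), while in place of 4-chlorophenyl it gives a 1.6-fold higher number from compound 2 to compound 4 (0.20 log units; within the scatter), so these two groups cannot be told apart here. With 3,4,5-trimethoxyphenyl on the amine nitrogen, the group on the aromatic carbon of the core also counts, since 3,4,5-trimethoxyphenyl in place of 4-methoxyphenyl gives an at least 9.8-fold lower number from compound 1 to compound 4 (0.99 log units; beyond the scatter). Compound 1 and compound 3 each stand at a limit and not at a number, so both of those steps are lower bounds: the limit of > 50000 nM in this assay, at which 2 of the 4 values shown sit.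

Still open, as far as these compounds go, is whether all three methoxy groups on either aryl group are needed. Also open, from the compounds shown here alone, is how a hydroxyl or an amine on the aryl group at the amine nitrogen, or a saturated alkyl chain in its place, would read in this assay.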